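This account rests on a few compounds, and the source may have more. Where it says the series, first, only, none or still open, it means among the compounds named here.

Measured so far in a functional assay on HeLa cells (Homo sapiens) for cytotoxicity; on this read-out higher numbers stand for lower toxicity in this test and lower numbers for higher toxicity in this test:
Compound 1 `CCCCCCCCOC(=O)C(O)Cn1cnc2c(N)ncnc21` gives 100 ug/mL.
Compound 2 `CC(C)COC(=O)C(O)Cn1cnc2c(N)ncnc21` gives > 400 ug/mL, which is a limit of the assay and not a number.
Compound 3 `CCCOC(=O)C(O)Cn1cnc2c(N)ncnc21` gives > 400 ug/mL, which is likewise a limit of the assay.

Compound 2 thus stands at the limit of > 400 ug/mL in this assay, at which 2 of the 3 values shown sit; its own number is not known, only that it sits at this limit together with compound 3, while compound 1 gives a number. The piece follows the step from compound 2 to compound 4 `Nc1ncnc2c1ncn2CC(O)C(=O)OCc1ccco1`. The change is furan-2-yl in place of isopropyl on a saturated chain carbon bound to an oxygen next to a carbonyl group.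

Of the measured steps, an at least 4.0-fold higher number from compound 1 to compound 2 (0.60 log units; beyond the scatter) and an at least 4.0-fold higher number from compound 1 to compound 3 (0.60 log units; beyond the scatter) both lead from the longest ester chain to a shorter one and end at the limit. The step that the two limits leave unreadable from compound 2 to compound 3 lies between two limits and cannot be read. None of these steps puts a ring in place of a chain, so they bear on the new step only loosely: they show that esters other than the heptyl one have reached the limit, and nothing shown points the other way.

The step from compound 2 to compound 4 is therefore expected to be an at least 1.3-fold lower number from compound 2 to compound 4 (0.12 log units; that floor lies within the scatter), most likely with compound 4 again reported only as a limit. Compound 4 is estimated at 300 ug/mL, within 100 ug/mL to 400 ug/mL. The measurement follows.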

Compound 4, minimum cytotoxic concentration: 40 ug/mL
Estimate against measurement, compound 4: 7.5-fold (0.88 log units) above, outside the stated range (below it).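

Until now, only the long chain of compound 1 had given a number in this assay, so a lower reading could have seemed to need a long chain at this position. The change from isopropyl to furan-2-yl, on a saturated chain carbon bound to an oxygen next to a carbonyl group, shows otherwise, with an at least 10-fold lower number from compound 2 to compound 4 (1.00 log units; beyond the scatter), and the straight short chain of compound 3 gives the same picture, with an at least 10-fold lower number from compound 3 to compound 4 (1.00 log units; beyond the scatter). The ring-bearing ester even goes past the long chain, with a 2.5-fold lower number from compound 1 to compound 4 (0.40 log units; beyond the scatter), so in this small set a compact ester with a ring gives higher toxicity in this test than the longest chain shown.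

From the compounds shown here alone, compound 2 and compound 3 are reported only as limits and not as numbers, so the true size of their steps to compound 4 stays open and the step between the two of them cannot be read: the limit of > 400 ug/mL in this assay, at which 2 of the 4 values shown sit. Whether any ring at this place would do the same, such as a phenyl or thiophene ring, or whether the furan ring and its oxygen matter, the compounds shown cannot tell.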